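Methoxycarbonyl to ethoxycarbonyl on the imidazolyl compound 3

This account rests on a few compounds, and the source may have more. Where it says the series, first, only, none or still open, it means among the compounds named here.

In a functional assay on the whole organism for agonist activity, with Mus musculus as the target (on this read-out lower numbers stand for an effect already at smaller amounts and higher numbers for an effect only at larger amounts of compound), compound 1 (`COC(=O)N(C)CC#CCn1ccnc1`) stands at 4.5 mg/kg and compound 2 (`COC(=O)N(C)C(C)C#CCN1CCCC1`) at 14.2 mg/kg, while compound 3 (`COC(=O)N(C)C(C)C#CCn1ccnc1`) stands at 8 mg/kg on the same scale. Compound 3 lies within the scatter of both other compounds, with a 1.8-fold higher number from compound 1 to compound 3 (0.25 log units; within the scatter) and a 1.8-fold lower number from compound 2 to compound 3 (0.25 log units; within the scatter) as the measured steps. The change to compound 4 (`CCOC(=O)N(C)C(C)C#CCn1ccnc1`) reads methyl in place of hydrogen on a saturated chain carbon bound to an oxygen next to a carbonyl group, turning methoxycarbonyl into ethoxycarbonyl. Within the data shown here, no measured step touches that place. Among the measured compounds shown here, the nearest precedent is another methyl in place of hydrogen on a different carbon, a 1.8-fold higher number from compound 1 to compound 3 (0.25 log units; within the scatter) and within the scatter. The expected step is therefore a 1.1-fold higher number from compound 3 to compound 4 (0.05 log units; within the scatter) in this assay, and no shift beyond the scatter is expected. For compound 4 the estimate is 9 mg/kg with an expected range from 4 mg/kg to 22 mg/kg in this read-out.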

Compound 4, dose for half-maximal effect: > 100 mg/kg
Compound 4 ended at the assay's limit; the forecaster's own chance of this, stated with the estimate: 10%; at least 11-fold (1.04 log units) between middle value and limit.
By their numbers in this assay, from the lowest: compounds 1, 3 and 2 (each within the scatter of the next, the first and the last beyond it). At a limit, above all of these: compound 4.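

Methoxycarbonyl to ethoxycarbonyl gives an at least 12-fold higher number from compound 3 to compound 4 (1.09 log units; beyond the scatter) in this assay, the only step shown that lies beyond the scatter. A methyl on a saturated chain carbon bound to an oxygen next to a carbonyl group thus matters far more here than the methyl on the chain carbon bound to the amide-type nitrogen, which gives a 1.8-fold higher number from compound 1 to compound 3 (0.25 log units; within the scatter). The full size of the step stays unknown, as the value of compound 4 is a limit: the limit of > 100 mg/kg in this assay, at which 1 of the 4 values shown sits.

As far as these compounds go, whether isopropoxycarbonyl, benzyloxycarbonyl or a carboxylic acid at this place would read like compound 3 or compound 4 remains open. Also open, from the compounds shown here alone, is whether ethoxycarbonyl has the same effect with the pyrrolidin-1-yl group of compound 2.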